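This account rests on a few compounds, and the source may have more. Where it says the series, first, only, none or still open, it means among the compounds named here.

The compounds measured so far, with their results in an assay on isolated protein for inhibition of alpha-galactosidase (Coffea arabica), tested at 1000 uM; a lower number here means less inhibition, a higher number more inhibition at the concentration tested (going by the name of the read-out):

compound 1, `COc1ccc([C@]2(CO)NC[C@@H](O)[C@@H]2O)cc1`: 7.5%
compound 2, `OC[C@]1(c2ccc(O)cc2)NC[C@H](O)[C@H]1O`: 3.6%
compound 3, `COc1cccc([C@@]2(CO)NC[C@H](O)[C@H]2O)c1`: 1.6%

Compound 1 carries the highest of the three numbers, yet the distance to compound 2 and the distance to compound 3 both fall within the usual scatter of this kind of measurement, so the three compounds cannot be separated from one another on these data. All three sit at the low end of the inhibition scale in this assay.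

The account now moves from compound 1 to compound 4, `OC[C@@]1(c2ccccc2)NC[C@@H](O)[C@@H]1O`. The change is a single one: hydrogen in place of methoxy on an aromatic carbon.

Going by the values given here, no pair of measured compounds differing in only one place is available, so nothing in the measured set shows what this particular change does. Since the three measured compounds vary in the group on the aromatic ring and in its position yet all give low inhibition that cannot be told apart, the expected step from compound 1 to compound 4 in this assay is a number 2.5 percentage points lower from compound 1 to compound 4 (within the scatter), meaning no change beyond the scatter in either direction.

Compound 4 is therefore estimated to give 5% in this assay, with a range from 0% to 15%.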

Compound 4, a percentage reported as inhibition, at one concentration (the size of the read-out at that concentration, not a potency): 9.9%
Compound 4: the middle estimate sits 4.9 percentage points below what was measured; measured number inside the range.
By their numbers in this assay, from the lowest: compounds 3, 2, 1 and 4 (each within the scatter of the next).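

Going by these compounds alone, this pair gives the first reading of a single change on the shared core: in this assay, hydrogen in place of methoxy on this aromatic carbon gives a number 2.4 percentage points higher from compound 1 to compound 4 (within the scatter) and so leaves the result unresolved from that of the methoxy compound. Within the data shown here, at this position, para to a group of 9 heavy atoms, the methoxy can therefore be taken away without the inhibition moving beyond the scatter, and compound 4 stays at the low end of the scale seen for the earlier compounds. No measurement of any other kind accompanies this pair, so nothing explains the size of the step.

From the compounds shown here alone, what a different group on this same aromatic carbon would do remains open, for instance an amine, a carboxylic acid or a longer alkoxy chain, and so does whether any of these would give a step beyond the scatter. Going by these compounds, it is equally open whether any change on this aromatic ring can lift the inhibition of the shared core clear of the low end of the scale in this assay at all.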